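Methyl to methoxy on the pendant phenyl of compound 2

The source may report more compounds than this note shows. Statements on the series, on what has been measured and on what is new or still open speak of the compounds shown alone.

The three measured compounds share one core and differ only in the placement of a methyl on the outer phenyl ring: compound 1 `Cc1ccccc1-c1cc(C)c(Nc2ccnc(Nc3ccc(C#N)cc3)n2)c(C)c1`, compound 2 `Cc1cccc(-c2cc(C)c(Nc3ccnc(Nc4ccc(C#N)cc4)n3)c(C)c2)c1` and compound 3 `Cc1ccc(-c2cc(C)c(Nc3ccnc(Nc4ccc(C#N)cc4)n3)c(C)c2)cc1`. In an ADME assay on MT4 cells (Homo sapiens) for cytotoxicity, read by MTT assay, with a stated time of 4 days (a higher number here means that more compound is tolerated, a lower number that less compound is tolerated), compound 1 gives 3820 nM, compound 2 gives 3670 nM and compound 3 gives 5570 nM. Compound 2 sits within the scatter of both neighbours: the step of a 1.0-fold lower number from compound 1 to compound 2 (0.02 log units; within the scatter) and the step of a 1.5-fold higher number from compound 2 to compound 3 (0.18 log units; within the scatter) are both within the scatter, as is the step of a 1.5-fold higher number from compound 1 to compound 3 (0.16 log units; within the scatter). Moving the methyl around the ring has therefore produced no change beyond the noise of this assay.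

Compound 4 `COc1cccc(-c2cc(C)c(Nc3ccnc(Nc4ccc(C#N)cc4)n3)c(C)c2)c1` differs from compound 2 by methoxy in place of methyl on an aromatic carbon. Within the data shown here, none of the measured steps involves a methoxy, so no measured pair speaks directly to this change; the only evidence is that small alterations on this ring so far have left the numbers flat. On that basis the step of a 1.0-fold higher number from compound 2 to compound 4 (0.00 log units; within the scatter) is expected to stay within the scatter. For compound 4 the estimate in this assay is 3700 nM, with a range from 1800 nM to 7500 nM.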

Compound 4, half-maximal cytotoxic concentration: 2990 nM
Beside the measured number, compound 4's estimate is 1.2-fold (0.09 log units) above it, within the range that was stated.
By their numbers in this assay, from the lowest: compounds 4, 2, 1 and 3 (each within the scatter of the next).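

In this assay, the methoxy in place of the methyl on the pendant ring (a 1.2-fold lower number from compound 2 to compound 4 (0.09 log units; within the scatter)) shows that this position accepts a group carrying a hydrogen-bond acceptor, which the methyl lacks, with no change beyond the scatter. The earlier compounds shown here varied only where a methyl sat, whereas this change alters the group itself, and compound 4 is also not separated from the other two methyl compounds (a 1.3-fold lower number from compound 1 to compound 4 (0.11 log units; within the scatter) and a 1.9-fold lower number from compound 3 to compound 4 (0.27 log units; within the scatter)), so all four compounds remain unresolved in this read-out. Nothing available explains this lack of separation or ties it to any property of the methyl or methoxy group.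

On these data alone, whether an amine or a carboxylic acid at this position would also leave the number within the scatter remains open, as does the effect of a longer chain such as ethoxy or propoxy. Also open, as far as these compounds go, is whether methoxy would give the same result as 2-methoxyphenyl or 4-methoxyphenyl, the placements that correspond to the methyl groups of compound 1 and compound 3.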